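The source may hold more compounds than are shown below. What is called first, only, known or untested is meant among the compounds shown, and "the series" means these compounds.

In a functional assay on HFF cells (Homo sapiens) for cytotoxicity (a lower number here means a stronger inhibitor, a higher number a weaker inhibitor), compound 1 (`CC(=O)OC1C(CF)OC(n2c(Cl)nc3cc(Cl)c(Cl)cc32)C1OC(C)=O`) gives 32000 nM and compound 2 (`CC(=O)OC1C(CBr)OC(n2c(Cl)nc3cc(Cl)c(Cl)cc32)C1OC(C)=O`) gives 32000 nM, while compound 3 (`CC(=O)OC1C(CI)OC(n2c(Cl)nc3cc(Cl)c(Cl)cc32)C1OC(C)=O`) gives 32000 nM and so stands level with both at the digits reported. The change to compound 4 (`CC(=O)OC1C(CN=[N+]=[N-])OC(n2c(Cl)nc3cc(Cl)c(Cl)cc32)C1OC(C)=O`) puts azido in place of iodo on a saturated chain carbon bound to a saturated ring carbon, so iodomethyl becomes azidomethyl. Three measured steps at that same place bear on it: no change at the digits printed from compound 1 to compound 2 (within the scatter) and no change at the digits printed from compound 1 to compound 3 (within the scatter) and also no change at the digits printed from compound 2 to compound 3 (within the scatter) and none of them moves the read-out. Going by the values given here, all three exchange one halogen for another, and no measured compound carries azido there, so the evidence is indirect. With compound 3 at 32000 nM as the starting point and no change at the digits printed from compound 2 to compound 3 (within the scatter) as the closest guide, no step beyond the scatter is expected in either direction. The expected outcome in this assay is no change at the digits printed from compound 3 to compound 4 (within the scatter) for this exchange. Compound 4 is estimated at 32000 nM with an expected range of 14000 nM to 64000 nM in this measurement.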

Compound 4, half-maximal inhibitory concentration: 32000 nM
Compound 4: the middle estimate sits on the measured number at the digits printed; low and high end bracket the measured number.
By their numbers in this assay, from the lowest: compounds 1, 2, 3 and 4 (each within the scatter of the next).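

In this assay, azido on a saturated chain carbon bound to a saturated ring carbon reads the same as each of the three halogens (no change at the digits printed from compound 3 to compound 4 (within the scatter); no change at the digits printed from compound 2 to compound 4 (within the scatter); no change at the digits printed from compound 1 to compound 4 (within the scatter)). The earlier compounds had only exchanged one halogen for another, whereas this exchange brings three nitrogen atoms to that place in place of a single halogen atom and the read-out still holds, so the flat picture now covers a group that is not a halogen, though only among these four compounds. Nothing available here explains this sameness.

The compounds shown leave open whether a group of another kind at this place, such as an amine, a carboxylic acid or a longer chain, would move the read-out. They also leave open whether a free hydroxyl in place of either acetate on the shared core would do so.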